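Compound 3: the ester of compound 2 removed

The source may report more compounds than this note shows. Statements on the series, on what has been measured and on what is new or still open speak of the compounds shown alone.

Among the measured compounds shown here, compound 2 `C/C=C/C(=O)OCC1=C[C@H](O)[C@@H](C(C)C)CC1=O` stands highest of the two numbers measured in a functional assay on A549 cells (Homo sapiens) for cytotoxicity, read by MTT assay, with a stated time of 4 days (on this read-out higher numbers stand for weaker inhibition and lower numbers for stronger inhibition), with 14000 nM; the only other measured compound, compound 1 `C/C=C/C(=O)OCC1=C[C@H](O)[C@@H](c2ccccc2)CC1=O`, gives 1300 nM in this assay, and the single measured step, an 11-fold higher number from compound 1 to compound 2 (1.03 log units; beyond the scatter), concerns a different place in the structure. Compound 3 `CC(C)[C@H]1CC(=O)C(CO)=C[C@@H]1O` differs from compound 2 by hydrogen in place of (prop-1-en-1-yl)carbonyl on an oxygen on a saturated carbon. For the measured compounds named here, no measured step bears on this change, so the expectation rests on compound 2 alone, and the step is expected to be a 1.8-fold higher number from compound 2 to compound 3 (0.25 log units; within the scatter) with a wide range. Compound 3 is therefore estimated at 25000 nM, between 5000 nM and 150000 nM.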

Compound 3, half-maximal inhibitory concentration: 159000 nM
For compound 3 the middle estimate is 6.4-fold (0.80 log units) below the measured one; measured number above the stated range.
By their numbers in this assay, from the lowest: compound 1; then compound 2; then compound 3.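

In this assay, among the compounds shown here, the change from ((prop-1-en-1-yl)carbonyl)oxy to hydroxy gives an 11-fold higher number from compound 2 to compound 3 (1.06 log units; beyond the scatter) and is the first measured step at this position. With isopropyl on the core, the free hydroxy does not hold the level of the ester. No measured evidence here accounts for this result.

Going by these compounds, whether the whole (prop-1-en-1-yl)carbonyl group is needed remains open, as an acetyl group or a methyl ether on this oxygen would test a smaller replacement. On these data alone, it is also open whether the step would be similar with phenyl in place of isopropyl.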